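Cytotoxicity notes on the amide series, compounds 1 to 4

The source may report more compounds than this note shows. Statements on the series, on what has been measured and on what is new or still open speak of the compounds shown alone.

Measured so far in an ADME assay on HELF cells (Homo sapiens) for cytotoxicity, with a stated time of 3 days; a lower number here means that less compound is tolerated, a higher number that more compound is tolerated:
- compound 1, `C[C@H](NC(=O)[C@]1(Cc2ccccc2)CCN1C(=O)Oc1cccc2ccccc12)C(N)=O`, gives > 100000 nM, which is a limit of the assay and not a number.
- compound 2, `C[C@H](NC(=O)[C@]1(Cc2ccccc2)CCN1C(=O)OCc1ccccc1)C(=O)NC1CCCCC1`, gives > 100000 nM, again a limit of the assay.
- compound 3, `CC(C)C[C@H](NC(=O)[C@@]1(Cc2ccccc2)CCN1C(=O)OCc1ccccc1)C(N)=O`, gives 66000 nM.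

Compound 2 thus stands at the limit of the assay in this assay, with no number attached; compound 1 sits at the same limit, and only compound 3 returns a number. Of the three values shown, the limit is where most of the series sits: the limit of > 100000 nM in this assay, at which 2 of the 3 values shown sit.

Compound 4, `C[C@H](NC(=O)[C@]1(Cc2ccccc2)CCN1C(=O)OCc1ccccc1)C(=O)N(C)C`, differs from compound 2 in one place: dimethylamino in place of cyclohexylamino on a carbonyl carbon. For the measured compounds named here, no step between measured compounds is on hand for this change, so nothing measured supports a direction. Given that compound 2 gives > 100000 nM, the expectation is no step beyond the scatter in this assay, with the estimated step from compound 2 to compound 4 being a number no higher from compound 2 to compound 4 (the limit leaves the size open). For compound 4 the estimate is 100000 nM, expected to lie between 50000 nM and 200000 nM, most likely reported again only as a limit.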

Compound 4, half-maximal cytotoxic concentration: > 100000 nM
Compound 4: only a limit was reported; the forecaster's own chance of this, stated with the estimate: 70%; the middle value sits exactly at the limit.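

In this assay compound 4 gives > 100000 nM, which is a limit of the assay. Compound 2 also stands at a limit, so no step can be read between compound 2 and compound 4. The compounds shown leave open whether dimethylamino in place of cyclohexylamino shifts the half-maximal cytotoxic concentration at all.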